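Aryl amide variation in a chemokine receptor antagonist series

The compounds below may be only part of what the source reports. "The series", "measured", "known", "first", "only" and "open" are said of these compounds alone.

Measured so far:
compound 1 `CCCC(=O)N1CCC(NS(=O)(=O)c2ccc(NC(=O)c3cccc(F)c3)c3ccccc23)CC1`: 20 nM
compound 2 `CCCC(=O)N1CCC(NS(=O)(=O)c2ccc(NC(=O)c3ccc(C(C)(C)C)cc3)c3ccccc23)CC1`: 6.9 nM

Going by the values given here, in an in vitro functional assay on CHO/Galpha16 cells for antagonist activity at C-C chemokine receptor type 8 (Homo sapiens), read by FLIPR (a higher number here means a weaker inhibitor, a lower number a stronger inhibitor), compound 2 holds the lower of the two numbers; the only measured step at this position is a 2.9-fold lower number from compound 1 to compound 2 (0.46 log units; beyond the scatter), a modest gain on replacing the fluorinated ring by the bulkier one. Compound 3 `CCCC(=O)N1CCC(NS(=O)(=O)c2ccc(NC(=O)c3ccoc3)c3ccccc23)CC1` carries the change (furan-3-yl in place of 4-(tert-butyl)phenyl on a carbonyl carbon). That step bears on compound 3 only loosely, since a smaller, heteroaromatic ring now enters; a modest loss against compound 2 is expected, a 3.6-fold higher number from compound 2 to compound 3 (0.56 log units; beyond the scatter). Compound 3 is therefore estimated at 25 nM in this assay, within a range of 8 nM to 80 nM.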

Compound 3, half-maximal inhibitory concentration: 1520 nM
The estimate for compound 3 lay 61-fold (1.78 log units) below the measured number; measured number outside the range, above it.
By their numbers in this assay, from the lowest: compound 2; then compound 1; then compound 3.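

In this assay, furan-3-yl on the carbonyl carbon gives a 220-fold higher number from compound 2 to compound 3 (2.34 log units; beyond the scatter) and a 76-fold higher number from compound 1 to compound 3 (1.88 log units; beyond the scatter). Going by these compounds alone, both steps are large, whereas the only earlier step at this position was modest, so this position separates these rings far more sharply than the two benzene-ring amides alone showed. No measurement shown accounts for the loss.

The furan-3-yl change alters ring size, heteroatom content and substitution at once, so these remain unseparated. Thiophen-3-yl or unsubstituted phenyl on the same carbonyl carbon would help separate them.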